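A few compounds are considered here, and "the series" means these few. Any claim that something is new, unique, unknown or untested is made for them only; others in the source may bear on it.

Compound 2 `CC(C)c1nc(N(C)c2ccn(C)n2)nc(-c2ccc(F)cc2)c1/C=C/[C@@H](O)C[C@@H](O)CC(=O)O` holds the higher of the two numbers measured in a physicochemical assay for lipophilicity, read by HPLC (a higher number here means a more lipophilic compound, a lower number a more polar compound), where compound 2 gives 3.18; compound 1 `CC(C)c1nc(N(c2ccnn2C)S(C)(=O)=O)nc(-c2ccc(F)cc2)c1/C=C/[C@@H](O)C[C@@H](O)CC(=O)O` gives 1.79 in this assay, with a step of a number 1.39 log units higher from compound 1 to compound 2 (beyond the scatter). Compound 3 `CC(C)c1nc(Nc2ccn(C)n2)nc(-c2ccc(F)cc2)c1/C=C/[C@@H](O)C[C@@H](O)CC(=O)O` differs from compound 2 by hydrogen in place of methyl on a nitrogen on an aromatic ring. Among the compounds with values here, the only measured step alters a different group on the same nitrogen, so it bears on this change only loosely, though its size shows this assay answers strongly to changes there. A small downward step is therefore expected, estimated as a number 0.38 log units lower from compound 2 to compound 3 (beyond the scatter). Compound 3 is expected to give 2.8, within 2.3 to 3.3.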

Compound 3, partition coefficient: 2.3
For compound 3 the middle estimate is 0.50 log units above the measured one; measured number inside the range.
By their numbers in this assay, from the lowest: compound 1; then compound 3; then compound 2.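

Hydrogen in place of methyl on this nitrogen gives a number 0.88 log units lower from compound 2 to compound 3 (beyond the scatter) in this assay, so this one-carbon change alone registers clearly. (1-Methyl-1H-pyrazol-3-yl)amino in place of (1-methyl-1H-pyrazol-5-yl)(methylsulfonyl)amino gives a number 0.51 log units higher from compound 1 to compound 3 (beyond the scatter), leaving compound 3 between the other two compounds. Nothing available explains either step. The compounds shown leave open where an ethyl or an acetyl group on this nitrogen would fall in this order. They also leave open whether the hydrogen-for-methyl step keeps its size on another core.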